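The compounds below may be only part of what the source reports. "The series", "measured", "known", "first", "only" and "open" are said of these compounds alone.

Measured so far in an ADME assay on microsomes from liver (Homo sapiens) for metabolic stability, tested at 2.5 uM; on this read-out lower numbers stand for slow clearance and higher numbers for fast clearance:

- compound 1, `COc1ccc(-c2c(S(=O)(=O)c3cccc(F)c3)cnc3c(F)cccc23)cc1`: 2.48 mL/min
- compound 2, `O=S(=O)(c1cc(F)cc(F)c1)c1cnc2c(F)cccc2c1-c1cccc(F)c1`: 1.18 mL/min
- compound 3, `O=S(=O)(c1cccc(F)c1)c1cnc2c(F)cccc2c1-c1ccc(F)cc1`: 0.19 mL/min

Compound 3 gives the lowest number of the three in this assay; compound 2 gives a higher number, and compound 1 gives the highest. Among the compounds with values here, the only single-change step measured so far is a 13-fold lower number from compound 1 to compound 3 (1.12 log units; beyond the scatter), which is fluoro in place of methoxy on an aromatic carbon.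

Compound 4, `O=S(=O)(c1cccc(F)c1)c1cnc2c(F)cccc2c1-c1cccc(F)c1`, has not yet been measured in this assay. It differs from compound 3 as follows: 3-fluorophenyl in place of 4-fluorophenyl on an aromatic carbon. The two compounds have the same atoms, joined differently.

Within the data shown here, no measured step bears on this change directly. Compound 2 also carries a 3-fluorophenyl and gives a higher number than compound 3, but compound 2 differs from compound 3 in two places, so its value cannot be read as the effect of this change alone. The step from compound 1 to compound 3 concerns a different position and does not inform this one.

Among the measured compounds shown here, with the only relevant information being the two values of compound 2 and compound 3, a modest rise in clearance is expected for compound 4, but within wide bounds. For compound 4 in this assay a value of 0.5 mL/min is estimated, with a range from 0.15 mL/min to 1.6 mL/min. The estimated step is a 2.6-fold higher number from compound 3 to compound 4 (0.42 log units; beyond the scatter).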

Compound 4, intrinsic clearance in a liver preparation (reported as CLH), per the amount of preparation that the assay uses: 1.14 mL/min
Compound 4: middle estimate off by 2.3-fold (0.36 log units), on the low side; low and high end bracket the measured number.
By their numbers in this assay, from the lowest: compound 3; then compounds 4 and 2 (each within the scatter of the next); then compound 1.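

In this assay, this place on the shared core, described as ortho to a fused ring and opposite the ring nitrogen, distinguishes between two groups with the same atoms: 3-fluorophenyl in place of 4-fluorophenyl gives a clear rise (a 6.0-fold higher number from compound 3 to compound 4 (0.78 log units; beyond the scatter)). The earlier drop on leaving 4-methoxyphenyl therefore does not extend to every fluorophenyl group at this place: 4-fluorophenyl gives a 13-fold lower number from compound 1 to compound 3 (1.12 log units; beyond the scatter), whereas 3-fluorophenyl gives only a 2.2-fold lower number from compound 1 to compound 4 (0.34 log units; beyond the scatter). Hydrogen in place of fluoro on the other aryl ring, with 3-fluorophenyl held constant, has no effect outside the scatter (a 1.0-fold lower number from compound 2 to compound 4 (0.01 log units; within the scatter)), so the higher number of compound 2 relative to compound 3 can now be tied to the 3-fluorophenyl group rather than to the added fluoro. Nothing shown explains why the location of the fluoro matters here.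

Still open, as far as these compounds go, is whether the same hydrogen-for-fluoro swap would be equally silent with 4-fluorophenyl in place. Also open, from the compounds shown here alone, is what a pyridyl ring, or a phenyl ring bearing an amine or a carboxylic acid, would give at this place.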